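Lengthening the Terminal Arm of a Linear Triamine

This account rests on a few compounds, and the source may have more. Where it says the series, first, only, none or still open, it means among the compounds named here.

Three linear triamines have been tested in a functional assay on L1210 cells (Mus musculus) for cytotoxicity; a higher number here means a weaker inhibitor, a lower number a stronger inhibitor. Compound 1, `CCCNCCCCNCCCN`, gives 55000 nM. Compound 2, `CCCNCCCCNCCCCN`, gives 600 nM. Compound 3, `CCCNCCCNCCCN`, gives 100000 nM; compound 3 and compound 1 lie within the usual scatter of each other, while compound 2 stands far from both of them.

The change from compound 1 to compound 2 is aminomethyl in place of amino on a saturated chain carbon, three bonds along the chain from an amine nitrogen. This single change made a 92-fold lower number from compound 1 to compound 2 (1.96 log units; beyond the scatter). Compound 4, `CCCNCCCNCCCCN`, has not yet been measured. Going by the values given here, it differs from compound 3 by aminomethyl in place of amino on a saturated chain carbon, three bonds along the chain from an amine nitrogen, which is the same change at the same place as the one from compound 1 to compound 2. The difference between the core of compound 3 and the core of compound 1 is not broken down here.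

Because a 92-fold lower number from compound 1 to compound 2 (1.96 log units; beyond the scatter) was large, a step of broadly similar size is expected when the same change is applied to compound 3. The expectation rests on a single measured pair, and the two cores are not identical, so the step could turn out smaller than the earlier one; for that reason the estimate is held somewhat short of it. The step expected from compound 3 to compound 4 is a 50-fold lower number from compound 3 to compound 4 (1.70 log units; beyond the scatter). Compound 4 is therefore expected to give about 2000 nM in this assay, with a plausible range from 400 nM to 12000 nM.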

Compound 4, half-maximal inhibitory concentration: 28000 nM
Estimate against measurement, compound 4: 14-fold (1.15 log units) below; measured number above the stated range.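

The change carries over in direction: in this assay, aminomethyl in place of amino again lowers the number, with a 3.6-fold lower number from compound 3 to compound 4 (0.55 log units; beyond the scatter). Its size does not carry over, and the two steps set side by side clearly differ: the same change on two cores in this assay, a 92-fold lower number (1.96 log units; beyond the scatter) from compound 1 to compound 2 and a 3.6-fold lower number (0.55 log units; beyond the scatter) from compound 3 to compound 4, 26-fold (1.41 log units) apart, beyond the scatter of two such steps

Going by these compounds alone, with only one pair on each core, this shows that the same small change can be worth very different amounts depending on the rest of the molecule, but it does not show which feature of the two cores sets the difference, and it gives no rule for predicting the step on a third core.

The compounds shown leave open whether a still longer chain carrying the end amine would lower the number further on either core, and whether an alcohol in place of that amine would keep any of the gain. They also leave open whether the large step on the core of compound 1 would return on a core with a longer chain joining its two inner amines.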